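Methyl to isopropyl on the acetyl of compound 3

A few compounds are considered here, and "the series" means these few. Any claim that something is new, unique, unknown or untested is made for them only; others in the source may bear on it.

Compound 3 `CC(=O)N1CCC[C@H]1C(=O)N1CCC(NS(=O)(=O)c2cc(S(=O)(=O)c3ccccc3)ccc2C(F)(F)F)CC1` in a functional assay on U2OS cells for antagonist activity at proto-oncogene Wnt-3 (Homo sapiens), read by a luciferase reporter, with a stated time of 18 h (a higher number here means that more compound is needed for the effect, a lower number that less compound is needed), gives 250 nM. Compound 1 `O=C(CN1CCNCC1)N1CCC(NS(=O)(=O)c2cc(S(=O)(=O)c3ccccc3)ccc2C(F)(F)F)CC1` gives 250 nM in this assay and compound 2 `O=C1CC[C@@H](C(=O)N2CCC(NS(=O)(=O)c3cc(S(=O)(=O)c4ccccc4)ccc3C(F)(F)F)CC2)N1` gives 240 nM; the steps of no change at the digits printed from compound 1 to compound 3 (within the scatter) and a 1.0-fold higher number from compound 2 to compound 3 (0.02 log units; within the scatter) both lie within the scatter, so compound 3 sits with the other two in one indistinguishable band of three numbers.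

Compound 4 `CC(C)C(=O)N1CCC[C@H]1C(=O)N1CCC(NS(=O)(=O)c2cc(S(=O)(=O)c3ccccc3)ccc2C(F)(F)F)CC1` differs from compound 3 by isopropyl in place of methyl on a carbonyl carbon. Among the measured compounds shown here, none of the measured steps touches this carbonyl carbon: a 1.0-fold lower number from compound 1 to compound 2 (0.02 log units; within the scatter), no change at the digits printed from compound 1 to compound 3 (within the scatter) and a 1.0-fold higher number from compound 2 to compound 3 (0.02 log units; within the scatter) exchange whole groups on a different carbonyl carbon and all stay within the scatter. For the measured compounds named here, the series therefore gives no direct precedent for methyl against isopropyl, and the only guidance is that three quite different groups in that region left this assay unchanged.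

The expectation for compound 4 is a step of no change at the digits printed from compound 3 to compound 4 (within the scatter), none beyond the scatter. Compound 4 is estimated at 250 nM in this assay, with a range from 120 nM to 550 nM.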

Compound 4, half-maximal effective concentration: 90 nM
Compound 4: the middle estimate sits 2.8-fold (0.44 log units) above what was measured; the measured number lies below the stated range.
By their numbers in this assay, from the lowest: compound 4; then compounds 2, 1 and 3 (each within the scatter of the next).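

In this assay, among the compounds shown here, isopropyl in place of methyl on this carbonyl carbon gives a 2.8-fold lower number from compound 3 to compound 4 (0.44 log units; beyond the scatter), the first step beyond the scatter; the exchanges among compound 1, compound 2 and compound 3 all stayed within it. The other two steps are of the same size, a 2.7-fold lower number from compound 2 to compound 4 (0.43 log units; beyond the scatter) and a 2.8-fold lower number from compound 1 to compound 4 (0.44 log units; beyond the scatter), so 1-(isopropylcarbonyl)pyrrolidin-2-yl stands apart from 5-oxopyrrolidin-2-yl and (piperazin-1-yl)methyl, whereas 1-acetylpyrrolidin-2-yl did not. Nothing available gives a reason for this step.

One pair, methyl and isopropyl, leaves open whether ethyl, tert-butyl or cyclopropyl on this carbonyl carbon would lower the number further. Also open, as far as these compounds go, is how an amine or a carboxylic acid carried on a longer chain at this carbonyl carbon would read.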